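The source may report more compounds than this note shows. Statements on the series, on what has been measured and on what is new or still open speak of the compounds shown alone.

Measured so far:
compound 1 `CC[C@H](C)Cn1c(Cc2cc(OC)c(OC)c(OC)c2)nc2c(N)nc(F)nc21` — 43700 nM
compound 2 `COc1cc(Cc2nc3c(N)ncnc3n2CC2CC2)cc(OC)c1OC` — 75900 nM
compound 3 `CCCCn1c(Cc2cc(OC)c(OC)c(OC)c2)nc2c(N)nc(F)nc21` — 24000 nM

In a functional assay on MCF7 cells (Homo sapiens) for antiproliferative activity (on this read-out higher numbers stand for weaker inhibition and lower numbers for stronger inhibition), compound 2 gives the highest of the three numbers, with compound 1 within the scatter of it and compound 3 beyond it. Compound 4 `COc1cc(Cc2nc3c(N)ncnc3n2CC2CCCO2)cc(OC)c1OC` is not yet measured; it differs from compound 2 by oxolan-2-yl in place of cyclopropyl on a saturated chain carbon bound to an aromatic nitrogen. Among the compounds with values here, the only measured step, a 1.8-fold lower number from compound 1 to compound 3 (0.26 log units; within the scatter), concerns hydrogen in place of methyl on a saturated chain carbon bound to two saturated chain carbons and lies within the scatter, so it bears only loosely on a ring exchange on the chain bound to the aromatic nitrogen. Within the data shown here, no measured pair tests that exchange. With nothing pointing either way, the expected step of a 1.3-fold lower number from compound 2 to compound 4 (0.10 log units; within the scatter) is none beyond the scatter. Compound 4 is therefore estimated at 60000 nM, range 20000 nM to 180000 nM.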

Compound 4, half-maximal inhibitory concentration: 91200 nM
Beside the measured number, compound 4's estimate is 1.5-fold (0.18 log units) below it; the measured number falls inside the stated range.
By their numbers in this assay, from the lowest: compounds 3, 1, 2 and 4 (each within the scatter of the next, the first and the last beyond it).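

In this assay, within the data shown here, oxolan-2-yl in place of cyclopropyl on a saturated chain carbon bound to an aromatic nitrogen gives a 1.2-fold higher number from compound 2 to compound 4 (0.08 log units; within the scatter), the first measured ring exchange at this place. A ring of 5 heavy atoms with 1 hydrogen-bond acceptor is thus tolerated here as well as cyclopropyl, with no shift beyond the scatter. Nothing available explains this result. Still open, as far as these compounds go, is whether a different kind of group at this place, such as an amine or a carboxylic acid, would move the number beyond the scatter.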